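Replacing the 1,2-oxazol-3-yl group of compound 2

The source may report more compounds than this note shows. Statements on the series, on what has been measured and on what is new or still open speak of the compounds shown alone.

Among the measured compounds shown here, in a physicochemical assay for solubility, in phosphate buffer, at pH 6.8 (a lower number here means a less soluble compound, a higher number a more soluble compound), compound 1 (`COc1ccccc1C1C(C(=O)C(C)(C)C)=C(O)C(=O)N1c1ccc(-c2ccon2)cc1`) gives 29600 nM and supplies the only true number so far. Compound 2 (`CC(C)(C)C(=O)C1=C(O)C(=O)N(c2ccc(-c3ccon3)cc2)C1c1ccccc1OCCO`) reads > 50000 nM and that is a limit of the assay, not a number. For the measured compounds named here, the single measured step runs an at least 1.6-fold higher number from compound 1 to compound 2 (0.22 log units; that floor lies within the scatter) and concerns the hydroxymethyl on the saturated chain, not the group at issue now.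

Compound 3 (`Cc1nc(-c2ccc(N3C(=O)C(O)=C(C(=O)C(C)(C)C)C3c3ccccc3OCCO)cc2)no1`) keeps that chain and carries 5-methyl-1,2,4-oxadiazol-3-yl in place of 1,2-oxazol-3-yl on an aromatic carbon, para to a large group. Going by the values given here, the counted difference is 5-methyl-1,2,4-oxadiazol-3-yl in place of 1,2-oxazol-3-yl on an aromatic carbon and it stands at a place that no measured step has touched. The data therefore give no direct size for this change, and only a modest shift is expected, toward a lower number if any. The nearest anchor is compound 1 at 29600 nM in this assay and the expectation leans on it. The expected step is an at least 1.4-fold lower number from compound 2 to compound 3 (0.15 log units; that floor lies within the scatter) and it is expected to stay close to the scatter. For compound 3 the estimate is 35000 nM as the expected value, within an estimated range from 12000 nM to 50000 nM as its upper end.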

Compound 3, solubility: > 50000 nM
Compound 3 was reported as a limit; the forecaster's own chance of this, stated with the estimate: 35%; middle value at least 1.4-fold (0.15 log units) away from the limit.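

In this assay compound 3 gives > 50000 nM as a limit of the assay and not a number. No size can be read for the change from compound 2 to compound 3, because both stop at the same limit: the limit of > 50000 nM in this assay, at which 2 of the 3 values shown sit. The compounds shown leave open whether 5-methyl-1,2,4-oxadiazol-3-yl in place of 1,2-oxazol-3-yl shifts solubility at all, and in which direction.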